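The source may hold more compounds than are shown below. What is called first, only, known or untested is meant among the compounds shown, and "the series" means these compounds.

Measured in a functional assay on MCF7 cells (Homo sapiens) for antiproliferative activity; on this read-out higher numbers stand for weaker inhibition and lower numbers for stronger inhibition:
- compound 1 `CC(C)=CCc1cc(C(=O)Nc2cc3ccc(OCC4CCN(C)C4)c(C)c3oc2=O)ccc1O` gives 1550 nM
- compound 2 `CC(C)=CCc1cc(C(=O)Nc2cc3ccc(OCCCN4CCCC4)c(C)c3oc2=O)ccc1O` gives 990 nM
- compound 3 `CC(C)=CCc1cc(C(=O)Nc2cc3ccc(OCCCNCCO)c(C)c3oc2=O)ccc1O` gives 1560 nM

Compound 2 has the lowest of the three numbers in this assay, but both other compounds sit within the scatter of it: a 1.6-fold lower number from compound 1 to compound 2 (0.19 log units; within the scatter) and a 1.6-fold higher number from compound 2 to compound 3 (0.20 log units; within the scatter). Compound 4 `CC(C)=CCc1cc(C(=O)Nc2cc3ccc(OCCCNCc4ccccc4)c(C)c3oc2=O)ccc1O` is not yet measured. It differs from compound 2 by benzylamino in place of pyrrolidin-1-yl on a saturated chain carbon, three bonds along the chain from an oxygen on an aromatic ring. Among the measured compounds shown here, the one measured step that bears on this place is the swap of pyrrolidin-1-yl for (2-hydroxyethyl)amino, which stayed within the scatter, and the broader replacement of the terminal group also stayed within the scatter: a 1.0-fold higher number from compound 1 to compound 3 (0.00 log units; within the scatter). No step beyond the scatter is therefore expected: a 1.2-fold higher number from compound 2 to compound 4 (0.08 log units; within the scatter). Compound 4 is estimated at 1200 nM, expected range 500 nM to 3000 nM.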

Compound 4, half-maximal inhibitory concentration: 910 nM
Estimate against measurement, compound 4: 1.3-fold (0.12 log units) above; the measured number falls inside the stated range.
By their numbers in this assay, from the lowest: compounds 4, 2, 1 and 3 (each within the scatter of the next).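

In this assay, the 3-(benzylamino)propyl chain, which brings a six-membered aromatic ring of carbon only, stays within the scatter of the 3-(pyrrolidin-1-yl)propyl chain (a 1.1-fold lower number from compound 2 to compound 4 (0.04 log units; within the scatter)). The same holds for phenyl in place of hydroxymethyl (a 1.7-fold lower number from compound 3 to compound 4 (0.23 log units; within the scatter)) and for 2-(benzylamino)ethyl in place of 1-methylpyrrolidin-3-yl (a 1.7-fold lower number from compound 1 to compound 4 (0.23 log units; within the scatter)), so no change at this place has yet left the scatter. No measurement is available to explain this flat result. Still open, from the compounds shown here alone, is whether a carboxylic acid in place of the amine, or a chain longer than propyl, would give a step beyond the scatter.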